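A few compounds are considered here, and "the series" means these few. Any claim that something is new, unique, unknown or untested is made for them only; others in the source may bear on it.

Compound 1, `O=C(N/N=C/c1ccccc1O)c1ccc(-c2ccc(F)cc2)o1`, gives 50300 nM in a functional assay on Bel-7402 cells (Homo sapiens) for antiproliferative activity, read by sulforhodamine B assay, with a stated time of 48 h; a higher number here means a weaker inhibitor, a lower number a stronger inhibitor.
Compound 2, `O=C(N/N=C/c1ccc(-c2ccc(F)cc2F)o1)c1ccccc1O`, gives 19300 nM in this assay.
Compound 3, `COc1ccccc1/C=N/NC(=O)c1ccc(-c2ccc(F)cc2F)o1`, gives 24600 nM in this assay.

Among these three numbers compound 2 stands lowest. The gap to compound 3 is small and falls within the usual scatter of repeated measurements, so the two cannot be ranked against each other; the gap to compound 1, however, lies beyond the scatter, and compound 1 is thus the weaker inhibitor of that pair.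

The step from compound 2 to compound 4, `O=C(N/N=C/c1ccc(-c2ccc(F)cc2)o1)c1ccccc1O`, is a single change: hydrogen in place of fluoro on an aromatic carbon. One fluorine atom leaves and a hydrogen takes its place; the rest of the molecule is untouched. For the measured compounds named here, no pair among the measured compounds shows this same change in isolation, so there is no directly comparable step to lean on. Given that a one-atom change of this kind rarely moves a number far, compound 4 is expected to land close to compound 2, perhaps a little higher, and the step from compound 2 to compound 4 is estimated as a 1.3-fold higher number from compound 2 to compound 4 (0.11 log units; within the scatter) in this assay. Compound 4 is therefore estimated at 25000 nM, with a range from 10000 nM to 60000 nM.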

Compound 4, half-maximal inhibitory concentration: 15200 nM
The estimate for compound 4 lay 1.6-fold (0.22 log units) above the measured number; the measured number falls inside the stated range.
By their numbers in this assay, from the lowest: compounds 4, 2 and 3 (each within the scatter of the next); then compound 1.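

The pair of compound 2 and compound 4 is the first among the compounds shown to differ in one place only, which isolates the change from 2,4-difluorophenyl to 4-fluorophenyl. In this assay this step reads as a 1.3-fold lower number from compound 2 to compound 4 (0.10 log units; within the scatter), so the fluoro group ortho to a large group can be taken away with no change that stands out from the scatter, and the two compounds cannot be ranked against each other. The data say only how small this step is, and nothing measured here gives a reason for it.

As far as these compounds go, it remains open whether a different replacement on this aromatic carbon, such as chloro, methoxy or an amine, would move the number beyond the scatter of compound 2 and compound 4, or whether a carboxylic acid or a longer chain there would do so. Also open, from the compounds shown here alone, is what happens at the remaining fluoro group of compound 4, and whether hydrogen, chloro or methoxy in its place would give a number clearly apart from that of compound 4.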